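The source may hold more compounds than are shown below. What is called first, only, known or untested is meant among the compounds shown, and "the series" means these compounds.

Measured in an ADME assay (liver) for metabolic stability, with Liver microsome (Rattus norvegicus) as the target, using microsomes and NADPH, with a stated time of 30 min, at 37 degrees C, tested at 1 uM; on this read-out lower numbers stand for slow clearance and higher numbers for fast clearance:

- Compound 1 `CC(O)(c1ccc(N2CCN(S(=O)(=O)c3ccc(N)nc3)CC2)cc1)C(F)(F)F`: < 14 mL.min-1.g-1
- Compound 2 `COc1cc(C(O)(C(F)(F)F)C(F)(F)F)cnc1-c1ccc(S(=O)(=O)c2ccc(N)nc2)cc1`: < 14 mL.min-1.g-1
- Compound 3 `CC(C)Nc1nc(S(=O)(=O)c2ccc(N)nc2)ccc1-c1ccc(C(C)(O)C(F)(F)F)cn1`: 62 mL.min-1.g-1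

Only one of these three results is an actual number. Compound 3 gives 62 mL.min-1.g-1, which places it on the side of faster clearance in this small set. Compound 1 and compound 2 both sit at a limit of the assay, (the limit of < 14 mL.min-1.g-1 in this assay, at which 2 of the 3 values shown sit). These two results are limits and not numbers.

The next compound to be tested is compound 4 `CC(O)(c1ccc(-c2ccc(S(=O)(=O)c3ccc(N)nc3)nc2Nc2cccnc2)nc1)C(F)(F)F`. It is built on compound 3, with pyridin-3-yl in place of isopropyl on a nitrogen on an aromatic ring. The same difference, cut one bond further out, reads isopropylamino to (pyridin-3-yl)amino.

Among the compounds with values here, none of the measured compounds forms a pair that differs in only one place, so no measured step shows what such a change does in this assay. The expectation therefore starts from compound 3 at 62 mL.min-1.g-1 and allows for wide uncertainty. The expected change is a 1.6-fold lower number from compound 3 to compound 4 (0.19 log units; within the scatter), leaning toward slower clearance but not beyond the usual scatter. For compound 4 the estimate is 40 mL.min-1.g-1, with an expected range of 15 mL.min-1.g-1 to 100 mL.min-1.g-1.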

Compound 4, intrinsic clearance in microsomes: 142 mL.min-1.g-1
Estimate against measurement, compound 4: 3.6-fold (0.55 log units) below, outside the stated range (above it).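

Pyridin-3-yl in place of isopropyl on a nitrogen on an aromatic ring is the first change in this set that can be read as a step, and in this assay it gives a 2.3-fold higher number from compound 3 to compound 4 (0.36 log units; beyond the scatter). This shows that the position is not indifferent on this read-out: exchanging isopropylamino for (pyridin-3-yl)amino moves the number toward faster clearance, although this single pair gives the direction for these two groups only. Nothing given here shows why the number rises with this exchange.

The compounds shown leave open how a phenyl group or a cyclopropyl group on this nitrogen would read, so the part played by the ring nitrogen of pyridin-3-yl cannot be separated from that of the aromatic ring itself or of the larger group. Compound 1 and compound 2 differ from compound 3 in more than one place and each gives a limit and not a number, so neither adds anything about this position: the limit of < 14 mL.min-1.g-1 in this assay, at which 2 of the 4 values shown sit.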